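Sulfur for oxygen at the aryl ether of compound 1

The source may report more compounds than this note shows. Statements on the series, on what has been measured and on what is new or still open speak of the compounds shown alone.

Compound 1 `Nc1cc(N)c2nc(-c3ccccc3)c(Oc3ccc(Cl)c(Cl)c3)nc2c1` is the weakest point among the three numbers in hand: in a functional assay on A498 cells (Homo sapiens) for inhibition, read by sulforhodamine B assay, with a stated time of 48 h (on this read-out higher numbers stand for weaker inhibition of growth and lower numbers for stronger inhibition of growth), compound 1 gives 91200 nM. Compound 2 `CCOC(=O)[C@H](CCC(=O)O)NC(=O)c1ccc(Sc2nc3cc(N)cc(N)c3nc2-c2ccccc2)cc1` gives 49000 nM in this assay, a value within the scatter of compound 1. Compound 3 `COc1cc(CNc2nc3cc(N)cc(N)c3nc2-c2ccccc2)cc(OC)c1OC` gives 6310 nM in this assay, clearly lower than compound 1. Compound 4 `Nc1cc(N)c2nc(-c3ccccc3)c(Sc3ccc(Cl)c(Cl)c3)nc2c1` carries the change ((3,4-dichlorophenyl)sulfanyl in place of 3,4-dichlorophenoxy on an aromatic carbon). For the measured compounds named here, no step between measured compounds bears directly on this change, and compound 2, the only other sulfur-linked aryl group, sits within the scatter of compound 1. In this assay the expected step is a 1.5-fold lower number from compound 1 to compound 4 (0.18 log units; within the scatter), not beyond the scatter. Compound 4 is expected to give 60000 nM, with a range from 20000 nM to 180000 nM.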

Compound 4, concentration for 50% growth inhibition: 17000 nM
Estimate against measurement, compound 4: 3.5-fold (0.55 log units) above; measured number below the stated range.
By their numbers in this assay, from the lowest: compound 3; then compound 4; then compounds 2 and 1 (each within the scatter of the next).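

In this assay, sulfur in place of the ether oxygen gives a 5.4-fold lower number from compound 1 to compound 4 (0.73 log units; beyond the scatter), so the linking atom alone moves the number beyond the scatter while the 3,4-dichlorophenyl ring and the shared core stay unchanged. For the compounds shown here, this single pair is the first direct reading of a change at this position. No measurement at hand accounts for the step.

Open, as far as these compounds go, is whether an amine link carrying the same 3,4-dichlorophenyl ring would read closer to compound 4 or compound 1. Also open, from the compounds shown here alone, is whether the sulfur step holds with an unsubstituted phenyl ring.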